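A few compounds are considered here, and "the series" means these few. Any claim that something is new, unique, unknown or untested is made for them only; others in the source may bear on it.

Compound 1 `CCCCCC(=O)c1ccn(-c2ccc3c(c2)B(O)OC3)c1` is the reference point of this short series. In an ADME assay on L929 cells (Mus musculus) for cytotoxicity, read by resazurin assay, with a stated time of 72 h (a lower number here means a stronger inhibitor, a higher number a weaker inhibitor), compound 1 gives > 10 ug/mL, which is a limit of the assay and not a number. Compound 2 `Cc1ccc(C(=O)c2ccn(-c3ccc4c(c3)B(O)OC4)c2)s1` carries 5-methylthiophen-2-yl in place of pentyl on a carbonyl carbon. In this assay compound 2 gives > 10 ug/mL, again only a limit. The step that the two limits leave unreadable from compound 1 to compound 2 is therefore unreadable in size, since both values sit at the limit of > 10 ug/mL in this assay, at which 2 of the 2 values shown sit. Among the measured compounds shown here, compound 1 thus stands at the limit, and nothing among the measured values places it more precisely.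

Compound 3 `OB1OCc2ccc(-n3ccc(Cc4ccccc4)c3)cc21` is the next candidate for this assay. It differs from compound 1 by benzyl in place of pentylcarbonyl on an aromatic carbon. For the measured compounds named here, the only measured step that touches the same part of the core is a step that the two limits leave unreadable from compound 1 to compound 2, and that step gave no readable size, so no direction can be derived from it. The expectation is that compound 3 also sits at the limit, with no step beyond the scatter. The estimate for compound 3 is 15 ug/mL, with a range from 5 ug/mL to 40 ug/mL. The expected step that the limit leaves unreadable from compound 1 to compound 3 is accordingly estimated as none beyond the scatter.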

Compound 3, half-maximal inhibitory concentration: > 10 ug/mL
Compound 3: no number, only a limit; the forecaster's own chance of this, stated with the estimate: 80%; the middle value is on the limit's open side.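

No new step can be read for compound 3 against compound 1 in this assay, since both give only a limit of the assay and not a number: the limit of > 10 ug/mL in this assay, at which 3 of the 3 values shown sit.

The compounds shown leave open where compound 1, compound 2 and compound 3 truly lie beyond that limit, and whether any of these changes on the shared core alters cytotoxicity.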